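The source may report more compounds than this note shows. Statements on the series, on what has been measured and on what is new or still open speak of the compounds shown alone.

Working notes on the series.

Compound 1 `CN(C)c1nc(N)nc2c1ncn2/C=C1/CC1(CO)CO` has no result in an ADME assay on MOLT-3 cells (Homo sapiens) for cytotoxicity, with a stated time of 7 days (on this read-out higher numbers stand for lower toxicity in this test and lower numbers for higher toxicity in this test), its entry being "not determined" (no result reported). Compound 2 `Nc1nc(NC2CCCCC2)c2ncn(/C=C3/CC3(CO)CO)c2n1` likewise stands at "not determined" (no result reported) in this assay. Compound 3 `CSc1nc(N)nc2c1ncn2/C=C1/CC1(CO)CO` returns a limit rather than a number in this assay, at > 20000 nM. Thus compound 1 stands with no single number of its own; of the remaining entries one is a limit and one carries no number, so the whole set gives the limit of > 20000 nM in this assay, at which 1 of the 3 values shown sits, as the only hard reference.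

Compound 4 `CCCCCOc1nc(N)nc2c1ncn2/C=C1/CC1(CO)CO` remains to be measured in this assay. Relative to compound 1 the change is pentyloxy in place of dimethylamino on an aromatic carbon. No measured step in this assay links any pair of these compounds, so no direction can be drawn from the series itself; the expectation is a step no larger than the usual scatter, in neither direction, with compound 4 sitting where compound 3 already sits, at the limit of the assay.

Compound 4 is accordingly expected to give about 40000 nM in this assay, within a range from 10000 nM to 200000 nM, most likely reported as a limit only.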

Compound 4, half-maximal cytotoxic concentration: > 20000 nM
Compound 4: no number, only a limit (the forecaster's own chance of this, stated with the estimate: 70%); the middle value is on the limit's open side.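

Compound 3 and compound 4 both return only limits in this assay, so no step can be read between them: the limit of > 20000 nM in this assay, at which 2 of the 4 values shown sit.

The compounds shown leave open where the half-maximal cytotoxic concentration of either compound lies, and whether pentyloxy in place of methylsulfanyl changes it at all.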